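Replacing Methoxy with Trifluoromethyl on the Pyridyl Arm

The compounds below may be only part of what the source reports. "The series", "measured", "known", "first", "only" and "open" are said of these compounds alone.

Compound 3 `COc1ccc(-c2nc(C(F)(F)F)sc2N2CCN(C(=O)Cn3nc(C)nc3C)[C@H](C)C2)cn1` gives 18 nM in a functional assay on CHO-K1 cells for antagonist activity at C-X-C chemokine receptor type 3 (Homo sapiens), read by FLIPR, with a stated time of 10 min (a higher number here means a weaker inhibitor, a lower number a stronger inhibitor), the second highest of the three numbers. Compound 1 `COc1ncc(-c2nc(C(F)(F)F)sc2N2CCN(C(=O)Cn3nc(C)nc3C)[C@H](C)C2)cn1` gives 25 nM, and a 1.4-fold lower number from compound 1 to compound 3 (0.14 log units; within the scatter). Compound 2 `Cc1nc(C)n(CC(=O)N2CCN(c3sc(C(F)(F)F)nc3-c3cnc(OC(C)C)nc3)C[C@H]2C)n1` gives 3.4 nM, with a 7.4-fold lower number from compound 1 to compound 2 (0.87 log units; beyond the scatter) and a 5.3-fold higher number from compound 2 to compound 3 (0.72 log units; beyond the scatter). Compound 4 `Cc1nc(C)n(CC(=O)N2CCN(c3sc(C(F)(F)F)nc3-c3ccc(C(F)(F)F)nc3)C[C@H]2C)n1` differs from compound 3 by trifluoromethyl in place of methoxy on an aromatic carbon. For the measured compounds named here, no measured step exchanges the methoxy for a group of this kind; the one step at the alkoxy position, a 7.4-fold lower number from compound 1 to compound 2 (0.87 log units; beyond the scatter), enlarged the alkoxy rather than removed it, and the ring swap from compound 1 to compound 3 stayed within scatter. The expected step is therefore a 1.7-fold higher number from compound 3 to compound 4 (0.22 log units; within the scatter), with wide uncertainty. Compound 4 is estimated at 30 nM, between 8 nM and 110 nM.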

Compound 4, half-maximal inhibitory concentration: 4.2 nM
The estimate for compound 4 lay 7.1-fold (0.85 log units) above the measured number, outside the stated range (below it).
By their numbers in this assay, from the lowest: compounds 2 and 4 (each within the scatter of the next); then compounds 3 and 1 (each within the scatter of the next).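

At this position an oxygen-linked group is not needed for a low number in this assay: trifluoromethyl on the pyridine ring gives a change beyond the scatter (a 4.3-fold lower number from compound 3 to compound 4 (0.63 log units; beyond the scatter)), and the same holds against the pyrimidine of compound 1 (a 6.0-fold lower number from compound 1 to compound 4 (0.77 log units; beyond the scatter)). The isopropoxy gain is thereby matched without any alkoxy group (a 1.2-fold higher number from compound 2 to compound 4 (0.09 log units; within the scatter)). No measurement offered here explains this step. As far as these compounds go, what a nitrile, a chlorine atom or an amine would do on this aromatic carbon stays open, as does whether trifluoromethyl in place of methoxy gives a like step on the 2-methoxypyrimidin-5-yl group of compound 1.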